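A few compounds are considered here, and "the series" means these few. Any claim that something is new, unique, unknown or untested is made for them only; others in the source may bear on it.

Working notes on the series. Of the compounds shown here, three of a shared core have been measured in a functional assay on EKVX cells (Homo sapiens) for inhibition; a higher number here means a weaker inhibitor of growth, a lower number a stronger inhibitor of growth. Compound 1 `O=C(/C=C/c1cccc(O)c1)c1cccc(-n2cc(-c3ccc(Cl)cc3)[nH]c2=O)c1` gives 2400 nM. Compound 2 `COc1cc(/C=C/C(=O)c2cccc(-n3cc(-c4ccccc4)[nH]c3=O)c2)cc(OC)c1OC` gives 2300 nM, which is the lowest number of the three, though its gap to compound 1 lies within the scatter, so no order between the two can be claimed. Compound 3 `COc1ccc(-c2cn(-c3cccc(C(=O)/C=C/c4ccc(O)c(OC)c4)c3)c(=O)[nH]2)cc1` gives 13400 nM; here the gap to compound 2 lies beyond the scatter, and compound 3 differs from compound 2 both at the aromatic carbon of the five-membered ring and on the enone-bearing aryl, so the two changes cannot be separated.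

Compound 4 `COc1cc(/C=C/C(=O)c2cccc(-n3cc(-c4cc(OC)c(OC)c(OC)c4)[nH]c3=O)c2)cc(OC)c1OC` has not yet been measured. It differs from compound 2 by 3,4,5-trimethoxyphenyl in place of phenyl on an aromatic carbon. Among the compounds with values here, no measured pair isolates this change. Within the data shown here, the only compound with a substituted aryl at that aromatic carbon, compound 3, carries the weaker number, so a moderate loss is expected, though a flat outcome cannot be excluded. The estimated step from compound 2 to compound 4 is a 2.0-fold higher number from compound 2 to compound 4 (0.29 log units; within the scatter) in this assay. Compound 4 is expected to give about 4500 nM, with a likely range from 1500 nM to 14000 nM.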

Compound 4, concentration for 50% growth inhibition: 9470 nM
The estimate for compound 4 lay 2.1-fold (0.32 log units) below the measured number; the measured number falls inside the stated range.
By their numbers in this assay, from the lowest: compounds 2 and 1 (each within the scatter of the next); then compounds 4 and 3 (each within the scatter of the next).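

In this assay, within the data shown here, the change at this position can now be read on its own for the first time. With the enone-bearing aryl held constant, 3,4,5-trimethoxyphenyl in place of phenyl on the aromatic carbon gives a 4.1-fold higher number from compound 2 to compound 4 (0.61 log units; beyond the scatter), a step beyond the scatter and so a real, modest loss of growth inhibition. This shows that the position is sensitive to the aryl group it carries, with phenyl the better of the two groups compared directly. Nothing shown accounts for this loss.

On these data alone, it remains open whether the loss needs all three methoxy groups, since no single-substituent aryl has been paired with the enone-bearing aryl of compound 2. How an amine or a carboxylic acid on this phenyl would behave is also unknown.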